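The source may report more compounds than this note shows. Statements on the series, on what has been measured and on what is new or still open speak of the compounds shown alone.

Compound 1 `COc1cc(OC)c(/C=C/S(=O)(=O)Cc2ccc(OC)c(N)c2)c(OC)c1`: 4 nM
Compound 2 `COC(=O)[C@H](C)Nc1cc(CS(=O)(=O)/C=C/c2c(OC)cc(OC)cc2OC)ccc1OC`: 750 nM
Compound 3 `COC(=O)C(C)(C)Nc1cc(CS(=O)(=O)/C=C/c2c(OC)cc(OC)cc2OC)ccc1OC`: 2500 nM

In a functional assay on DU-145 cells (Homo sapiens) for cytotoxicity, read by trypan blue exclusion, with a stated time of 96 h (on this read-out lower numbers stand for stronger inhibition and higher numbers for weaker inhibition), compound 3 gives the highest number of the three: a 630-fold higher number from compound 1 to compound 3 (2.80 log units; beyond the scatter) and a 3.3-fold higher number from compound 2 to compound 3 (0.52 log units; beyond the scatter) both lie beyond the scatter. Compound 4 `COC(=O)C(Nc1cc(CS(=O)(=O)/C=C/c2c(OC)cc(OC)cc2OC)ccc1OC)c1ccc(Cl)cc1` differs from compound 3 in one place: (4-chlorophenyl)(methoxycarbonyl)methyl in place of 1-(methoxycarbonyl)-1-methylethyl on a nitrogen on an aromatic ring. Among the compounds with values here, the steps that bear on this change are a 190-fold higher number from compound 1 to compound 2 (2.27 log units; beyond the scatter), a 630-fold higher number from compound 1 to compound 3 (2.80 log units; beyond the scatter) and a 3.3-fold higher number from compound 2 to compound 3 (0.52 log units; beyond the scatter). Each substitution on the nitrogen on the aromatic ring has raised the number in this assay, and the bulkier group raised it further. The entering group is larger again, so a further rise is expected, though its size is uncertain because a 3.3-fold higher number from compound 2 to compound 3 (0.52 log units; beyond the scatter) was only modest. Compound 4 is therefore expected to give about 4500 nM, between 1000 nM and 18000 nM, a step of a 1.8-fold higher number from compound 3 to compound 4 (0.26 log units; within the scatter).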

Compound 4, half-maximal inhibitory concentration: 400 nM
The estimate for compound 4 lay 11-fold (1.05 log units) above the measured number, outside the stated range (below it).
By their numbers in this assay, from the lowest: compound 1; then compounds 4 and 2 (each within the scatter of the next); then compound 3.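

In this assay, a larger group on a nitrogen on an aromatic ring does not always give a higher number: (4-chlorophenyl)(methoxycarbonyl)methyl reverses the earlier rise (a 6.3-fold lower number from compound 3 to compound 4 (0.80 log units; beyond the scatter)) and cannot be told apart from 1-(methoxycarbonyl)ethyl (a 1.9-fold lower number from compound 2 to compound 4 (0.27 log units; within the scatter)). Even so, it remains far from hydrogen at this position (a 100-fold higher number from compound 1 to compound 4 (2.00 log units; beyond the scatter)). Nothing available explains the reversal. The compounds shown leave open whether the chlorine is needed, as a plain phenyl ring would show, and how a carboxylic acid in place of the methyl ester would read.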